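Series notes: methyl to ethyl, compound 3 to compound 4

This account rests on a few compounds, and the source may have more. Where it says the series, first, only, none or still open, it means among the compounds named here.

Measured in a functional assay on KG-1 cells (Homo sapiens) for antiproliferative activity, read by CCK-8 assay, with a stated time of 72 h; a lower number here means a stronger inhibitor, a higher number a weaker inhibitor:
- compound 1 `Cc1ccc(C(=O)Nc2cccc(C(F)(F)F)c2)cc1-c1ccc2c(-c3ccc(CN4CCN(C)CC4)cc3)n[nH]c2c1`: 120 nM
- compound 2 `Cc1ccc(C(=O)Nc2cccc(C(F)(F)F)c2)cc1-c1ccc2c(-c3cn[nH]c3)n[nH]c2c1`: > 1000 nM (a limit of the assay, not a number)
- compound 3 `Cc1ccc(C(=O)Nc2cccc(C(F)(F)F)c2)cc1-c1ccc2c(-c3cnn(C)c3)n[nH]c2c1`: 65.7 nM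

Going by the values given here, compound 1 at 120 nM and compound 3 at 65.7 nM lie within the scatter of each other, and these are the only two numbers in the set. Compound 2 is known only as the limit > 1000 nM.

Compound 4 `CCn1cc(-c2n[nH]c3cc(-c4cc(C(=O)Nc5cccc(C(F)(F)F)c5)ccc4C)ccc23)cn1` departs from compound 3 by methyl in place of hydrogen on a saturated chain carbon bound to an aromatic nitrogen, that is, 1-methyl-1H-pyrazol-4-yl to 1-ethyl-1H-pyrazol-4-yl.

Among the compounds with values here, one measured step bears on this change, and only indirectly: an at least 15-fold lower number from compound 2 to compound 3 (1.18 log units; beyond the scatter). That large step placed methyl in place of hydrogen on the aromatic nitrogen itself, and it starts from a limit. In the new change that nitrogen already carries a chain, and the added methyl sits one carbon further out. Within the data shown here, no measured step covers this kind of lengthening, so the large step is not carried over, and no change beyond the scatter is expected in this assay. The expected step, an estimate only, is a 1.1-fold higher number from compound 3 to compound 4 (0.06 log units; within the scatter). For compound 4 the estimated value is 75 nM, with an expected range of 30 nM to 190 nM.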

Compound 4, half-maximal inhibitory concentration: 257 nM
Beside the measured number, compound 4's estimate is 3.4-fold (0.53 log units) below it; measured number outside the range, above it.
By their numbers in this assay, from the lowest: compounds 3 and 1 (each within the scatter of the next); then compound 4. At a limit, above all of these: compound 2.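

In this assay, the saturated chain carbon bound to an aromatic nitrogen turns out to be a place where a small addition counts: methyl in place of hydrogen there gives a 3.9-fold higher number from compound 3 to compound 4 (0.59 log units; beyond the scatter). Going by these compounds alone, the earlier compounds showed only what a first methyl on the aromatic nitrogen does, so this is the first reading on how far the group on that nitrogen can grow, and in this pair the change from 1-methyl-1H-pyrazol-4-yl to 1-ethyl-1H-pyrazol-4-yl goes the unfavourable way. Ethyl in place of hydrogen on the aromatic nitrogen still gives an at least 3.8-fold lower number from compound 2 to compound 4 (0.59 log units; beyond the scatter), so compound 4 keeps part of the gain over compound 2, but that step starts from a limit of the assay and its full size stays unknown: the limit of > 1000 nM in this assay, at which 1 of the 4 values shown sits.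

Whether the trend continues with a propyl chain or a branched isopropyl group on the same nitrogen is open, since one lengthening step does not define a trend. Also open, from the compounds shown here alone, is whether a chain ending in a hydroxyl group or a tertiary amine would follow ethyl or depart from it.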